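Methyl on the piperidine ring: compound 3 to compound 4

A few compounds are considered here, and "the series" means these few. Any claim that something is new, unique, unknown or untested is made for them only; others in the source may bear on it.

Measured so far in a functional assay on MDA-MB-231 cells (Homo sapiens) for inhibition, read by MTT assay, with a stated time of 48 h; on this read-out higher numbers stand for weaker inhibition and lower numbers for stronger inhibition:
compound 1 `COc1ccc(Nc2ncc3c(n2)N(C2CCCC2)CC(=O)N3C)cc1` gives > 30000 nM; this is a limit of the assay.
compound 2 `CC1CCN(c2ccc(Nc3ncc4c(n3)N(C3CCCC3)CC(=O)N4)cc2)CC1` gives 22700 nM.
compound 3 `CN1C(=O)CN(C2CCCC2)c2nc(Nc3ccc(N4CCCCC4)cc3)ncc21` gives 21200 nM.

Compound 3 holds the lowest of the two numbers shown in this assay, but compound 2 sits within the scatter of it, so no order between the two can be read. The value of compound 1 is only a limit (the limit of > 30000 nM in this assay, at which 1 of the 3 values shown sits).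

Within the data shown here, the single measured step, an at least 1.4-fold lower number from compound 1 to compound 3 (0.15 log units; that floor lies within the scatter), concerns the group on the aromatic carbon and does not reach into the saturated ring. Compound 4 `CC1CCN(c2ccc(Nc3ncc4c(n3)N(C3CCCC3)CC(=O)N4C)cc2)CC1` differs from compound 3 by methyl in place of hydrogen on a saturated ring carbon. Among the measured compounds shown here, no measured step covers this change. Compound 2 carries the same 4-methylpiperidin-1-yl, yet it also differs from compound 3 in the lactam, so the two values show only that they lie within the scatter of each other.

On this footing no step beyond the scatter is expected in this assay from compound 3 to compound 4. Compound 4 is estimated at 20000 nM, with a range from 8000 nM to 50000 nM. The expected step of a 1.1-fold lower number from compound 3 to compound 4 (0.03 log units; within the scatter) is within the scatter, and a limit rather than a number remains possible.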

Compound 4, half-maximal inhibitory concentration: > 30000 nM
Compound 4: no number, only a limit (the forecaster's own chance of this, stated with the estimate: 25%); middle value at least 1.5-fold (0.17 log units) from the limit.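

Methyl in place of hydrogen on the saturated ring carbon, three ring bonds from the ring nitrogen, now has its first comparison in one place in this assay: an at least 1.4-fold higher number from compound 3 to compound 4 (0.15 log units; that floor lies within the scatter). This change brings no reading below the number of compound 3, although the floor of the step stays within the scatter, so no loss can be claimed either. The lactam nitrogen, the other place in which compound 4 differs from a measured neighbour, gives an at least 1.3-fold higher number from compound 2 to compound 4 (0.12 log units; that floor lies within the scatter), which is again only a floor within the scatter, and the step from compound 1 to compound 4 cannot be read, as both compounds stand at a limit: the limit of > 30000 nM in this assay, at which 2 of the 4 values shown sit.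

From the compounds shown here alone, with compound 4 at a limit, the true size of both readable steps stays open, and so does whether either methyl changes the number at all. Also open, going by these compounds, is how this assay would read with an amine, a carboxylic acid or a longer chain such as ethyl on this same ring carbon of the piperidine.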